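This account rests on a few compounds, and the source may have more. Where it says the series, first, only, none or still open, it means among the compounds named here.

Series notes. Compound 1 `Cc1cccc(Oc2cccc(COc3ccccc3CCC(=O)OCCCOP(=O)(O)OC[C@H](N)C(=O)O)c2)c1` in an assay on HEK293 cells for agonist activity at probable G-protein coupled receptor 34 (Homo sapiens), with a stated time of 1 h (a lower number here means a smaller maximal response, a higher number a larger maximal response), gives 24.2%. Among the compounds with values here, compound 2 `Cc1ccc(Oc2cccc(COc3ccccc3CCC(=O)OCCCOP(=O)(O)OC[C@H](N)C(=O)O)c2)cc1` gives in this assay 22.1%; this is the lower of the two numbers measured so far, but the only step in the set, a number 2.1 percentage points lower from compound 1 to compound 2 (within the scatter), is within the scatter, so compound 1 and compound 2 cannot be ordered against each other. Compound 3 `CC(C)(C)c1ccc(Oc2cccc(COc3ccccc3CCC(=O)OCCCOP(=O)(O)OC[C@H](N)C(=O)O)c2)cc1` has not yet been measured. Its difference from compound 2: tert-butyl in place of methyl on an aromatic carbon. Within the data shown here, no measured step touches this kind of change; the one step on record exchanges 4-methylphenyl for 3-methylphenyl on the oxygen and leaves the largest response unmoved beyond the scatter. The shared core is the same in all three compounds. Among the measured compounds shown here, with nothing in the set that would move the number, the step of a number 1.9 percentage points higher from compound 2 to compound 3 (within the scatter) is expected to stay within the scatter, and the range is kept wide because the change has no precedent here. For compound 3 the estimate in this assay is 24%, from 10% to 42%.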

Compound 3, largest response reached (Emax), in percent of the reference or control that the assay uses: 28.2%
The estimate for compound 3 lay 4.2 percentage points below the measured number; measured number inside the range.
By their numbers in this assay, from the lowest: compounds 2, 1 and 3 (each within the scatter of the next).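

In this assay, going from methyl to tert-butyl on the aromatic carbon, from one heavy atom to four, gives a step that stays within the scatter (a number 6.1 percentage points higher from compound 2 to compound 3 (within the scatter)). The exchange of 3-methylphenyl for 4-(tert-butyl)phenyl on the oxygen reads the same way (a number 4 percentage points higher from compound 1 to compound 3 (within the scatter)). The earlier pair showed only that moving a methyl leaves the largest response unresolved; this result adds that a much larger all-carbon group at this place, para to a large group, also gives no step beyond the scatter, so across compounds 1, 2 and 3 neither the size of this group nor the exchange of 3-methylphenyl for 4-(tert-butyl)phenyl separates the numbers, and nothing measured here offers an explanation for that.

Open, on these data alone, is whether a group on this carbon that is not a plain hydrocarbon, such as an amine, a carboxylic acid or a methoxy group, would move the largest response beyond the scatter. Also open, as far as these compounds go, is whether changes away from this ring, such as a longer chain within the shared core, would do so, since all three compounds keep that core unchanged.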